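The source may hold more compounds than are shown below. What is called first, only, known or untested is meant among the compounds shown, and "the series" means these compounds.

Compound 1 `CN(C)C(=O)c1cc2cnc(Nc3ccc(NC(=O)C4(C(=O)Nc5ccc(Cl)cc5)CC4)cc3)nc2n1C1CCCC1`: 95.7%
Compound 2 `CN(C)C(=O)c1cc2cnc(Nc3ccc(NC(=O)C4(C(=O)Nc5cccc(F)c5)CC4)cc3)nc2n1C1CCCC1`: 98.8%
Compound 3 `CN(C)C(=O)c1cc2cnc(Nc3ccc(NC(=O)C4(C(=O)Nc5cccc(O)c5)CC4)cc3)nc2n1C1CCCC1`: 94.9%

In a functional assay on NCI-H460 cells (Homo sapiens) for inhibition, read by CCK-8 assay, with a stated time of 72 h, tested at 10 uM (on this read-out higher numbers stand for more inhibition of growth at the one concentration tested and lower numbers for less inhibition of growth), compound 3 gives 94.9%, which lies within the scatter of both other compounds, so the three cannot be ranked. Compound 4 `CN(C)C(=O)c1cc2cnc(Nc3ccc(NC(=O)C4(C(=O)Nc5cccc(Cl)c5)CC4)cc3)nc2n1C1CCCC1` has chloro in place of hydroxy on an aromatic carbon of a six-membered aromatic ring of carbon only, meta to a large group: chloro in place of hydroxy on an aromatic carbon. For the measured compounds named here, three measured steps bear on this change. The most direct is hydroxy in place of fluoro on an aromatic carbon, a number 3.9 percentage points lower from compound 2 to compound 3 (within the scatter). Exchanging the whole aryl group on the amide-type nitrogen gave a number 3.1 percentage points higher from compound 1 to compound 2 (within the scatter) and a number 0.8 percentage points lower from compound 1 to compound 3 (within the scatter). All three steps stay within the scatter, so no step beyond the scatter is expected in this assay, and no direction can be favoured. The expected step is a number 1.1 percentage points higher from compound 3 to compound 4 (within the scatter). Compound 4 is estimated at 96%. The expected range for compound 4 runs from 90% to 100%.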

Compound 4, percent growth inhibition at one concentration: 101%
Compound 4: middle estimate off by 5 percentage points, on the low side; the whole stated range lies below it.
By their numbers in this assay, from the lowest: compounds 3, 1, 2 and 4 (each within the scatter of the next).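

In this assay, chloro in place of hydroxy on this aromatic carbon gives a number 6.1 percentage points higher from compound 3 to compound 4 (within the scatter) and so is the largest step seen so far at this position, yet it still does not separate the two compounds. Chloro in place of fluoro gives a number 2.2 percentage points higher from compound 2 to compound 4 (within the scatter) and 3-chlorophenyl in place of 4-chlorophenyl gives a number 5.3 percentage points higher from compound 1 to compound 4 (within the scatter) so neither the group exchanged here nor the place of the chlorine shows a difference in this read-out. No independent evidence bears on these results.

As far as these compounds go, the four compounds were compared at one concentration only, so whether they would separate at a lower concentration stays open. Also open, from the compounds shown here alone, is whether an amine, a carboxylic acid or a methoxy group on this carbon would stay within the same scatter.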